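Aryl swaps on the core of compound 1 in KM12 cells

The source may report more compounds than this note shows. Statements on the series, on what has been measured and on what is new or still open speak of the compounds shown alone.

Compound 1 `COc1ccc(-c2cn3ccnc3c(-c3ccc4ncn(C5CCCCC5)c4c3)n2)cc1`: 83.2%
Compound 2 `Fc1ccccc1-c1cn2ccnc2c(-c2ccc3ncn(C4CCCCC4)c3c2)n1`: 2.45%
Compound 3 `c1csc(-c2cn3ccnc3c(-c3ccc4ncn(C5CCCCC5)c4c3)n2)c1`: 4.89%

In a functional assay on KM12 cells (Homo sapiens) for inhibition, read by sulforhodamine B assay, with a stated time of 48 h, tested at 10 uM (on this read-out higher numbers stand for more inhibition at the one concentration tested (going by the name of the read-out) and lower numbers for less inhibition), compound 1 stands highest of the three numbers; compound 3 is nearest and compound 2 furthest. Both changes away from 4-methoxyphenyl cost heavily: a number 80.8 percentage points lower from compound 1 to compound 2 (beyond the scatter) and a number 78.3 percentage points lower from compound 1 to compound 3 (beyond the scatter). Between the two lower compounds the step of a number 2.4 percentage points higher from compound 2 to compound 3 (within the scatter) stays within the scatter.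

Compound 4 `FC(F)(F)c1cccc(-c2cn3ccnc3c(-c3ccc4ncn(C5CCCCC5)c4c3)n2)c1` differs from compound 1 by 3-(trifluoromethyl)phenyl in place of 4-methoxyphenyl on an aromatic carbon. The two measured steps that bear on this change, 1 to 2 and 1 to 3, were both large drops, so a large drop is also expected here, namely a number 71.2 percentage points lower from compound 1 to compound 4 (beyond the scatter). For compound 4 the estimate is 12%, with a range from 0% to 45%.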

Compound 4, a percentage reported as inhibition, at one concentration (the size of the read-out at that concentration, not a potency): 1.25%
Compound 4: middle estimate off by 10.8 percentage points, on the high side; low and high end bracket the measured number.
By their numbers in this assay, from the lowest: compounds 4, 2 and 3 (each within the scatter of the next); then compound 1.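

In (this assay) a third aryl replacement, 3-(trifluoromethyl)phenyl, also loses the inhibition seen with 4-methoxyphenyl (a number 82 percentage points lower from compound 1 to compound 4 (beyond the scatter)). The three replacements now form a single low group, with no separation beyond the scatter (a number 3.6 percentage points lower from compound 3 to compound 4 (within the scatter); a number 1.2 percentage points lower from compound 2 to compound 4 (within the scatter)). Nothing available explains the loss.

Still open, as far as these compounds go, is whether the activity depends on the methoxy group itself or on its place on the phenyl ring. An amine or a longer ether chain on that ring would help to test this.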